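The source may report more compounds than this note shows. Statements on the series, on what has been measured and on what is new or still open speak of the compounds shown alone.

Measured compounds:
compound 1, `CC(O)(CSc1ccc(C(F)(F)F)cc1)C(=O)Nc1ccc(S(F)(F)(F)(F)F)cc1`, 28800 nM
compound 2, `CC(O)(CSc1cccc(C(F)(F)F)c1)C(=O)Nc1ccc(S(F)(F)(F)(F)F)cc1`, 26200 nM
compound 3, `CC(O)(CSc1ccc(OC(F)(F)F)cc1)C(=O)Nc1ccc(S(F)(F)(F)(F)F)cc1`, 12500 nM

In a functional assay on DU-145 cells (Homo sapiens) for antiproliferative activity, read by propidium iodide staining, with a stated time of 96 h (a higher number here means a weaker inhibitor, a lower number a stronger inhibitor), compound 1 gives 28800 nM, compound 2 gives 26200 nM and compound 3 gives 12500 nM. Compound 4, `CC(O)(CSc1cccc(OC(F)(F)F)c1)C(=O)Nc1ccc(S(F)(F)(F)(F)F)cc1`, has not yet been measured. The cores of compound 1 and compound 2 differ by 3-(trifluoromethyl)phenyl in place of 4-(trifluoromethyl)phenyl on a sulfur, which gave a 1.1-fold lower number from compound 1 to compound 2 (0.04 log units; within the scatter). The change from compound 1 to compound 3 is trifluoromethoxy in place of trifluoromethyl on an aromatic carbon, and it brought a 2.3-fold lower number from compound 1 to compound 3 (0.36 log units; beyond the scatter). The same kind of change, though not the same one, leads from compound 2 to compound 4: trifluoromethoxy in place of trifluoromethyl on an aromatic carbon, where the place is meta to a large group rather than para to a large group. Because the earlier step was a 2.3-fold lower number from compound 1 to compound 3 (0.36 log units; beyond the scatter), a step of a 2.2-fold lower number from compound 2 to compound 4 (0.34 log units; beyond the scatter) is expected here. Compound 4 is estimated at 12000 nM, expected to fall between 6000 nM and 24000 nM.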

Compound 4, half-maximal inhibitory concentration: 23800 nM
For compound 4 the middle estimate is 2.0-fold (0.30 log units) below the measured one; the range from low to high includes it.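

In this assay, trifluoromethoxy in place of trifluoromethyl gave a 1.1-fold lower number from compound 2 to compound 4 (0.04 log units; within the scatter), a step that cannot be told apart from repeat measurement. Set beside the same change on the core of compound 1, this step does not differ reliably from the earlier one: the same change on two cores in this assay, a 2.3-fold lower number (0.36 log units; beyond the scatter) from compound 1 to compound 3 and a 1.1-fold lower number (0.04 log units; within the scatter) from compound 2 to compound 4, 2.1-fold (0.32 log units) apart, within the scatter of two such steps The two steps therefore do not show that the change depends on the core, nor do they establish that it carries over with one fixed size, and two steps cannot fix its size on a further core.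

The compounds shown leave open what a nitrile, a chlorine or an amine would do in place of these two fluorinated groups. Also open, going by these compounds, is how a sulfone would compare with the sulfur link.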